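The source may report more compounds than this note shows. Statements on the series, on what has been measured and on what is new or still open speak of the compounds shown alone.

Compound 3, `O=C(NCCCCn1cccn1)c1cccc(C2SCC(=O)N2c2cc(Cl)ccn2)c1`, stands lowest of the three compounds measured in a functional assay on HOS-TE85 cells (Homo sapiens) for inhibition, read by CCK-8 assay, with a stated time of 72 h (a lower number here means a stronger inhibitor, a higher number a weaker inhibitor), where compound 3 gives 36.4 nM. The other two sit above it: compound 1, `COc1ccccc1N1C(=O)CSC1c1cccc(C(=O)NCCCCn2cccn2)c1`, gives 91.7 nM in this assay, and compound 2, `O=C(NCCCCn1cccn1)c1cccc(C2SCC(=O)N2c2cc(Br)ccn2)c1`, gives 105 nM. The measured steps show a 2.5-fold lower number from compound 1 to compound 3 (0.40 log units; beyond the scatter) and a 2.9-fold lower number from compound 2 to compound 3 (0.46 log units; beyond the scatter), both beyond the scatter, while a 1.1-fold higher number from compound 1 to compound 2 (0.06 log units; within the scatter).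

Compound 4, `O=C(NCCCCn1cccn1)c1cccc(C2SCC(=O)N2c2cc(F)ccn2)c1`, differs from compound 3 in one place: fluoro in place of chloro on an aromatic carbon. Among the measured compounds shown here, only one of the measured steps bears directly on this change, namely a 2.9-fold lower number from compound 2 to compound 3 (0.46 log units; beyond the scatter), a halogen exchange on an aromatic carbon of the same ring. That step was modest, and nothing measured tells how a fluoro substituent behaves at this position. He therefore expects a 1.2-fold higher number from compound 3 to compound 4 (0.09 log units; within the scatter), most likely within the scatter, with a small chance of a further modest lowering or of a return toward the number of compound 2. In this assay compound 4 is estimated at 45 nM, with a range from 18 nM to 110 nM.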

Compound 4, half-maximal inhibitory concentration: 33.2 nM
Compound 4: middle estimate off by 1.4-fold (0.13 log units), on the high side; the range from low to high includes it.
By their numbers in this assay, from the lowest: compounds 4 and 3 (each within the scatter of the next); then compounds 1 and 2 (each within the scatter of the next).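

In this assay, fluoro in place of chloro on the carbon opposite the ring nitrogen gives no separable change (a 1.1-fold lower number from compound 3 to compound 4 (0.04 log units; within the scatter)), so at this position the two halogens cannot be told apart. Fluoro in place of bromo gives a clear step (a 3.2-fold lower number from compound 2 to compound 4 (0.50 log units; beyond the scatter)), and with the chloro in place of bromo step (a 2.9-fold lower number from compound 2 to compound 3 (0.46 log units; beyond the scatter)) this shows that, of the three halogens, bromo alone stands apart here, now on two separate comparisons rather than one. The 4-fluoropyridin-2-yl group also improves on the 2-methoxyphenyl group (a 2.8-fold lower number from compound 1 to compound 4 (0.44 log units; beyond the scatter)), as the 4-chloropyridin-2-yl group does, while the 4-bromopyridin-2-yl group of compound 2 goes against this pattern (a 1.1-fold higher number from compound 1 to compound 2 (0.06 log units; within the scatter)), so the gain over compound 1 depends on the halogen and does not follow from the pyridine ring alone.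

As far as these compounds go, whether a plain pyridin-2-yl with hydrogen at this carbon, or a methyl, methoxy, amino or nitrile group there, would sit with chloro and fluoro or with bromo stays open. Nothing among the data shown offers an explanation for why bromo parts from the other two halogens.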